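From a 4-bromophenyl to a 2,5-dichlorophenyl amide

A few compounds are considered here, and "the series" means these few. Any claim that something is new, unique, unknown or untested is made for them only; others in the source may bear on it.

Values measured in a functional assay on HCT-116 cells (Homo sapiens) for inhibition, read by MTT assay, with a stated time of 2 days (a higher number here means a weaker inhibitor of growth, a lower number a stronger inhibitor of growth), are as follows.

Compound 1 `Nc1ccccc1NC(=O)CCCNCC(=O)Nc1cccc(Cl)c1` gives 75000 nM
Compound 2 `Nc1ccccc1NC(=O)CCCNCC(=O)Nc1ccc(Br)cc1` gives 55500 nM
Compound 3 `Nc1ccccc1NC(=O)c1ccc(NCC(=O)Nc2cccc([N+](=O)[O-])c2)cc1` gives 9000 nM

On these numbers, compound 2 at 55500 nM lies within the scatter of compound 1. The number is clearly lower for compound 3 at 9000 nM in this assay. Compound 4 `Nc1ccccc1NC(=O)CCCNCC(=O)Nc1cc(Cl)ccc1Cl` has not yet been measured. It differs from compound 2 by a single change (2,5-dichlorophenyl in place of 4-bromophenyl on an amide-type nitrogen), with 2,5-dichlorophenyl in place of 4-bromophenyl on an amide-type nitrogen.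

Among the compounds with values here, only one measured step bears directly on this change. It alters the group at the same place, and it is a 1.4-fold lower number from compound 1 to compound 2 (0.13 log units; within the scatter). Within the data shown here, compound 3 has a different core, so it offers no comparable step. Among the measured compounds shown here, none of the measured compounds carries a 2,5-dichlorophenyl group, which leaves the evidence thin. Even so, the one relevant step gives no ground for expecting a change beyond the scatter, and it favours no direction. The expected result is a 1.1-fold lower number from compound 2 to compound 4 (0.05 log units; within the scatter) in this assay. For compound 4 the estimated value is 50000 nM, with an expected range from 22000 nM to 110000 nM.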

Compound 4, concentration for total growth inhibition: 78000 nM
Estimate against measurement, compound 4: 1.6-fold (0.19 log units) below; low and high end bracket the measured number.
By their numbers in this assay, from the lowest: compound 3; then compounds 2, 1 and 4 (each within the scatter of the next).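

In this assay, the exchange at this position is a 1.4-fold higher number from compound 2 to compound 4 (0.15 log units; within the scatter), and the added chlorine on the aromatic ring gives a 1.0-fold higher number from compound 1 to compound 4 (0.02 log units; within the scatter). Until now, the position on the amide-type nitrogen had been probed only by exchanging one singly halogenated phenyl group for another; the 2,5-dichlorophenyl group shows that a second halogen also leaves the number within the scatter, with the 3-chlorophenyl, 4-bromophenyl and 2,5-dichlorophenyl amides indistinguishable on the shared core. No measurement on hand explains why these three compounds stay together.

On these data alone, all three groups at this position are halogenated phenyl groups, so it remains open whether a methoxy group, an amine or a carboxylic acid on the phenyl ring of the shared core would give a step beyond the scatter. Compound 3, at 9000 nM, differs from these compounds in more than one place, which leaves open whether its clearly lower number would survive placing a nitro group on the phenyl ring of the core of compound 1.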